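The compounds below may be only part of what the source reports. "The series", "measured", "known", "first", "only" and "open" are said of these compounds alone.

Series notes. Compound 1 `COc1ccc(-c2cc3ccccc3nc2C=O)cc1` is the short member of the set. In a functional assay on NCI-H460 cells (Homo sapiens) for antiproliferative activity, read by XTT assay, with a stated time of 72 h (on this read-out lower numbers stand for stronger inhibition and higher numbers for weaker inhibition), compound 1 returns only a limit, > 10000 nM, and no number. Compound 2 `COc1ccc(-c2cc3ccccc3nc2/C=C/C(=O)c2ccccc2)cc1` keeps the core of compound 1 and carries a longer arm ending in a benzoyl group. In this assay, among the measured compounds shown here, compound 2 gives 6670 nM, the only number so far. The other entry in this assay is the limit at which compound 1 sits (the limit of > 10000 nM in this assay, at which 1 of the 2 values shown sits). Compound 2 therefore stands alone as the one measured point of reference, with nothing above or below it to set a trend.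

Compound 3 `COc1ccc(-c2cc3ccccc3nc2/C=C/C(=O)c2ccc(F)cc2)cc1` is the next compound, awaiting measurement in this assay. Its difference from compound 2 is a single substitution, (fluoro in place of hydrogen on an aromatic carbon). One heavy atom enters and no ring, donor or acceptor is added. For the measured compounds named here, no measured pair shows what such a substitution does, so there is no basis for predicting a shift beyond the scatter. The step expected a 1.2-fold lower number from compound 2 to compound 3 (0.08 log units; within the scatter) is small, within the usual scatter. Compound 3 is expected to give about 5500 nM, in a range from 2000 nM to 15000 nM.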

Compound 3, half-maximal inhibitory concentration: 6990 nM
Beside the measured number, compound 3's estimate is 1.3-fold (0.10 log units) below it, within the range that was stated.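

Fluoro in place of hydrogen on an aromatic carbon, para to a large group, gives the first single-place change in the series that can be read in this assay, and the step is a 1.0-fold higher number from compound 2 to compound 3 (0.02 log units; within the scatter). Phenyl and 4-fluorophenyl at the end of the arm therefore cannot be told apart on this read-out, so this one fluorine atom gives this position its first reading, and that reading is a null one, which compound 2 alone could not supply. Compound 1 still offers only a limit of the assay and no number, so the series rests on two numbers that lie within the scatter of each other, and the other entry stays as it was: the limit of > 10000 nM in this assay, at which 1 of the 3 values shown sits.

Going by these compounds, whether this ring position responds to anything other than fluoro stays open, since a single atom says little about what an amine, a carboxylic acid or a longer chain at the same place would do in this assay. Also open, on these data alone, is which part of the longer arm, the carbonyl or the chain leading to it, matters for the number in compound 2.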